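Ring swap on the amine side of a common core

The source may report more compounds than this note shows. Statements on the series, on what has been measured and on what is new or still open speak of the compounds shown alone.

Measured so far:
compound 1 `COc1ccc(Cl)cc1CN[C@H]1[C@H](C(C)(C)C)[C@@H](C(=O)O)N(C(=O)C2CCCCC2)[C@H]1c1ccccc1` gives 109% in an assay on HBE cells for positive allosteric modulation of Cystic fibrosis transmembrane conductance regulator variant F508del (Homo sapiens); on this read-out higher numbers stand for larger maximal responses and lower numbers for smaller maximal responses;
compound 2 `COc1ccc(C(C)C)cc1CN[C@H]1[C@H](C(C)(C)C)[C@@H](C(=O)O)N(C(=O)C2CCCCC2)[C@H]1c1ccccc1` gives 191%;
compound 3 `COc1ccc(C(C)(C)C)cc1CN[C@H]1[C@H](C(C)(C)C)[C@@H](C(=O)O)N(C(=O)C2CCCCC2)[C@H]1c1ccccc1` gives 195%.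

Compound 1 stands lowest of the three; its nearest neighbour is compound 2, the furthest compound 3. Compound 4 `COc1ncc(C(F)(F)F)cc1CN[C@H]1[C@H](C(C)(C)C)[C@@H](C(=O)O)N(C(=O)C2CCCCC2)[C@H]1c1ccccc1` differs from compound 1 by 2-methoxy-5-(trifluoromethyl)pyridin-3-yl in place of 5-chloro-2-methoxyphenyl on a saturated chain carbon bound to an amine nitrogen. The bearing steps are a number 82 percentage points higher from compound 1 to compound 2 (beyond the scatter) and a number 86 percentage points higher from compound 1 to compound 3 (beyond the scatter), both large rises when chloro gives way to an alkyl group, while a number 4 percentage points higher from compound 2 to compound 3 (within the scatter) stays within the scatter. Within the data shown here, no measured step covers a trifluoromethyl or a ring nitrogen, so the analogy is loose. A rise is nonetheless expected for compound 4, estimated as a number 41 percentage points higher from compound 1 to compound 4 (beyond the scatter), with a wide range. The expected value for compound 4 is 150%, between 100% and 200%.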

Compound 4, largest response reached (reported as percent of maximum), in percent of the reference or control that the assay uses: 85%
The estimate for compound 4 lay 65 percentage points above the measured number, outside the stated range (below it).
By their numbers in this assay, from the lowest: compound 4; then compound 1; then compounds 2 and 3 (each within the scatter of the next).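

Replacing the aryl group on the saturated chain carbon bound to an amine nitrogen with 2-methoxy-5-(trifluoromethyl)pyridin-3-yl lowers the response in this assay: a number 24 percentage points lower from compound 1 to compound 4 (beyond the scatter) and sits under the chloro analogue. The alkyl-bearing aryl groups stand far higher, with a number 106 percentage points lower from compound 2 to compound 4 (beyond the scatter) and a number 110 percentage points lower from compound 3 to compound 4 (beyond the scatter), so this position does not reward every larger group. Nothing available explains the fall.

From the compounds shown here alone, the ring nitrogen and trifluoromethyl enter together, so their separate contributions remain open. A 5-tert-butyl-2-methoxypyridin-3-yl or 2-methoxy-5-(trifluoromethyl)phenyl group would divide them.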